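The source may hold more compounds than are shown below. What is called first, only, known or untested is meant among the compounds shown, and "the series" means these compounds.

Compound 1 `CC(C)(C)NC(=O)c1c(N)sc(-c2ccc(Cl)cc2)c1-c1ccc(Cl)cc1` gives 8850 nM here
Compound 2 `Nc1sc(-c2ccc(Cl)cc2)c(-c2ccc(Cl)cc2)c1C(=O)NCc1ccccc1` gives 16300 nM here

In a functional assay on A549 cells (Homo sapiens) for inhibition, read by sulforhodamine B assay, with a stated time of 72 h (a higher number here means a weaker inhibitor, a lower number a stronger inhibitor), compound 2 stands at 16300 nM and compound 1 at 8850 nM in the same read-out, so the two lie within the scatter of each other. For the measured compounds named here, they are the only measured compounds, and they share a core carrying the same amide. Compound 3 `Nc1sc(-c2ccc(Cl)cc2)c(-c2ccc(Cl)cc2)c1C(=O)NC1CC1` is not yet measured. It differs from compound 2 as follows: cyclopropyl in place of benzyl on an amide-type nitrogen. Going by the values given here, only one measured step bears on this position: a 1.8-fold higher number from compound 1 to compound 2 (0.27 log units; within the scatter), with benzyl in place of tert-butyl on that same nitrogen. Among the compounds with values here, that step stays inside the scatter, but it is a single step, and no measured compound carries cyclopropyl. A step beyond the scatter is therefore not expected in this assay, and no direction is firmly indicated. The expected step is a 1.4-fold lower number from compound 2 to compound 3 (0.13 log units; within the scatter), which is an estimate and no more. For compound 3 the estimated value is 12000 nM, with an expected range from 5000 nM to 30000 nM in this read-out.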

Compound 3, half-maximal inhibitory concentration: 1950 nM
Compound 3: the middle estimate sits 6.2-fold (0.79 log units) above what was measured; the whole stated range lies above it.
By their numbers in this assay, from the lowest: compound 3; then compounds 1 and 2 (each within the scatter of the next).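

The amide nitrogen proved to be a position where the substituent can change the reading, which the earlier pair did not show, since tert-butyl and benzyl there lay within the scatter of each other. In this assay, cyclopropyl in place of benzyl gives an 8.4-fold lower number from compound 2 to compound 3 (0.92 log units; beyond the scatter), and cyclopropyl in place of tert-butyl gives a 4.5-fold lower number from compound 1 to compound 3 (0.66 log units; beyond the scatter), so both steps lie beyond the scatter and compound 3 is the strongest inhibitor of the three. No evidence is available on what underlies this gain.

The compounds shown cannot say whether the gain belongs to the three-membered ring itself or would also appear with another small group on this nitrogen, such as methyl, ethyl or cyclobutyl, or with a chain ending in an amine or a hydroxyl. As far as these compounds go, the rest of the shared core is the same in all three compounds, so it also remains open whether the cyclopropyl step would keep its size with other groups on that core.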